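The compounds below may be only part of what the source reports. "The series", "measured", "known", "first", "only" and "open" are said of these compounds alone.

The measured compounds:
Compound 1, `C=C1CCCC(C)(C)C1CC[C@]1(C)CC[C@H]([C@@H](C)C(=O)OC)OO1`, 6430 nM
Compound 2, `C=C1CCC[C@H]2[C@](C)(CC[C@]3(C)CC[C@@H]([C@@H](C)C(=O)O)OO3)[C@@H](C)CC[C@]12C`, > 5000 nM
Compound 3, `C=C1CCCC(C)(C)C1(O)CC/C(C)=C/CC[C@]1(C)CC[C@@H]([C@@H](C)C(=O)OC)OO1`, > 17500 nM

In a functional assay on M14 cells (Homo sapiens) for inhibition (a higher number here means a weaker inhibitor of growth, a lower number a stronger inhibitor of growth), compound 1 gives 6430 nM. For compound 2 the result in this assay is only a limit, > 5000 nM, and no number stands beneath it. For compound 3 the result in this assay is likewise a limit, > 17500 nM. Among the measured compounds shown here, compound 2 therefore stands at the limit of > 5000 nM in this assay, at which 1 of the 3 values shown sits, with one other compound also at a limit, (the limit of > 17500 nM in this assay, at which 1 of the 3 values shown sits), and compound 1 as the only one with a measured number.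

The account turns from compound 2 to compound 4, `C=C1CCC[C@H]2[C@](C)(CC[C@]3(C)CC[C@H]([C@@H](C)C(=O)O)OO3)[C@@H](C)CC[C@]12C`. The change is small: the two compounds have the same atoms and bonds and differ only in configuration as drawn: 1 of 7 stereo elements differ; a stereocentre at a saturated ring carbon is drawn S in compound 2 and R in compound 4. Nothing leaves and nothing enters. For the measured compounds named here, no step between two measured compounds is available to calibrate a change of this kind, so the expectation rests on compound 2 alone, which sits at a limit. An inversion at one saturated ring carbon is expected to move this assay little, if at all beyond the usual scatter, and compound 4 is expected to remain near the limit where compound 2 stands. The expected step from compound 2 to compound 4 in this assay is a step that the limit leaves unreadable from compound 2 to compound 4. Compound 4 is thus estimated at 8000 nM, within a range from 3000 nM to 30000 nM.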

Compound 4, concentration for 50% growth inhibition: 3290 nM
The estimate for compound 4 lay 2.4-fold (0.39 log units) above the measured number; low and high end bracket the measured number.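

In this assay, the inversion at this saturated ring carbon now has a first reading, an at least 1.5-fold lower number from compound 2 to compound 4 (0.18 log units; that floor lies within the scatter). For compound 2 the result is only a limit, > 5000 nM. Compound 4 carries a measured number, 3290 nM. A change at this one stereocentre is all that stands between the two compounds of this pair: the fact that compounds 2 and 4 differ only in the configuration as drawn.

How far the true step lies past that floor remains unread, and with it whether the inversion moves this assay beyond the usual scatter at all. Whether the same inversion would give a similar reading with a primary amide or a longer chain in place of the carboxylic acid is also left open by the compounds shown.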